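Oxazole ketone series: pyridyl headgroup variation against fatty-acid amide hydrolase

A few compounds are considered here, and "the series" means these few. Any claim that something is new, unique, unknown or untested is made for them only; others in the source may bear on it.

Compound 1 `O=C(O)c1ccc(-c2cnc(C(=O)CCc3ccc(-c4ccccc4)cc3)o2)cn1` gives 44 nM in an assay for inhibition of Fatty-acid amide hydrolase 1 (Rattus norvegicus); on this read-out higher numbers stand for weaker inhibition and lower numbers for stronger inhibition. Compound 2 `COC(=O)c1ccc(-c2cnc(C(=O)CCc3ccc(-c4ccccc4)cc3)o2)nc1` gives 2.2 nM. Compound 3 `O=C(O)c1ccc(-c2cnc(C(=O)CCc3ccc(-c4ccccc4)cc3)o2)nc1` gives 14 nM.

Compound 3 stands second highest of the three numbers, the step being a 3.1-fold lower number from compound 1 to compound 3 (0.50 log units; beyond the scatter) and a 6.4-fold higher number from compound 2 to compound 3 (0.80 log units; beyond the scatter). Compound 4 `N#Cc1cccc(-c2cnc(C(=O)CCc3ccc(-c4ccccc4)cc3)o2)n1` differs from compound 3 by 6-cyanopyridin-2-yl in place of 5-carboxypyridin-2-yl on an aromatic carbon. For the measured compounds named here, no measured step shows a nitrile. The nearest comparison is the acid to ester step, a 6.4-fold higher number from compound 2 to compound 3 (0.80 log units; beyond the scatter), where removing the hydrogen-bond donor in this assay gave the lower number. The move to a group with no donor is therefore expected to give a lower number, a 3.5-fold lower number from compound 3 to compound 4 (0.54 log units; beyond the scatter), with wide uncertainty. Compound 4 is estimated at 4 nM, range 1.2 nM to 14 nM.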

Compound 4, inhibition constant: 2.9 nM
Estimate against measurement, compound 4: 1.4-fold (0.14 log units) above, within the range that was stated.
By their numbers in this assay, from the lowest: compounds 2 and 4 (each within the scatter of the next); then compound 3; then compound 1.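

In this assay, the acid is not needed at this aromatic carbon next to the ring oxygen: 6-cyanopyridin-2-yl gives a 4.8-fold lower number from compound 3 to compound 4 (0.68 log units; beyond the scatter) and a 15-fold lower number from compound 1 to compound 4 (1.18 log units; beyond the scatter). The nitrile and the ester read alike, with a 1.3-fold higher number from compound 2 to compound 4 (0.12 log units; within the scatter), so among these four compounds both acids carry the higher numbers, and no compound goes against this. Nothing here bears on the cause of these steps.

Compound 4 changes both the group and its place on the pyridine ring, and these two changes remain unseparated. From the compounds shown here alone, how a primary amide or an amine on that ring would read also stays open.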